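Chain-end variation on a shared chlorinated core

The source may report more compounds than this note shows. Statements on the series, on what has been measured and on what is new or still open speak of the compounds shown alone.

Measured compounds:
compound 1 `CCNC1=Nc2ccc(Cl)cc2C(C)(C)C1`: in a functional assay on MDA-MB-231 cells (Homo sapiens) for cytotoxicity, read by MTT assay, with a stated time of 72 h, tested at 5 uM, in the absence of a further agent (a lower number here means a stronger effect, a higher number a weaker effect of the compound at the concentration tested), compound 1 gives 85.1%
compound 2 `CC1(C)CC(NCCCCO)=Nc2ccc(Cl)cc21`: in this assay compound 2 gives 84.9%

Both measured compounds leave most of the cells viable at the test concentration, so the effect in this assay is weak for either. Compound 2 stands level with compound 1, its only comparator; the step of a number 0.2 percentage points lower from compound 1 to compound 2 (within the scatter) is within the scatter, so no ordering of the two can be stated.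

Compound 3 `CN(C)CCCNC1=Nc2ccc(Cl)cc2C(C)(C)C1` is not yet measured. It differs from compound 2 by dimethylamino in place of hydroxymethyl on a saturated chain carbon, three bonds along the chain from an amine nitrogen. For the measured compounds named here, no measured step exchanges one chain-end group for another of this kind. Going by the values given here, the only step on record, a number 0.2 percentage points lower from compound 1 to compound 2 (within the scatter), extends the chain on the amine nitrogen and leaves the read-out unchanged, which gives no sign that the chain end governs the number in this assay. The expectation is therefore no step beyond the scatter, a number 2.9 percentage points lower from compound 2 to compound 3 (within the scatter), with the width of the range reflecting the absence of a direct precedent. Compound 3 is estimated at 82%, with a range from 62% to 96%.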

Compound 3, a percentage reported as activity, at one concentration (the size of the read-out at that concentration, not a potency): 38%
Beside the measured number, compound 3's estimate is 44 percentage points above it; the measured number lies below the stated range.
By their numbers in this assay, from the lowest: compound 3; then compounds 2 and 1 (each within the scatter of the next).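

In this assay, the group at the chain end, three bonds along the chain from an amine nitrogen, proves able to move the read-out strongly: dimethylamino in place of hydroxymethyl gives a number 46.9 percentage points lower from compound 2 to compound 3 (beyond the scatter). Set against compound 1, the 3-(dimethylamino)propyl chain gives a number 47.1 percentage points lower from compound 1 to compound 3 (beyond the scatter), whereas the 4-hydroxybutyl chain gives a number 0.2 percentage points lower from compound 1 to compound 2 (within the scatter), so among these three compounds a longer chain on the amine nitrogen does not by itself go with a large step, and only the chain carrying dimethylamino does. The data on hand offer no measurement that accounts for this step.

The compounds shown leave open whether the step belongs to dimethylamino specifically or would also appear with a primary amine, diethylamino or a methoxy group at the same chain end. They also leave open how the read-out depends on the length of the chain carrying dimethylamino, whether a shorter chain or a longer one, and whether the number of compound 3, 38%, holds at other concentrations.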